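This account rests on a few compounds, and the source may have more. Where it says the series, first, only, none or still open, it means among the compounds named here.

Of the compounds shown here, three have been measured in an assay on Sf9 cells for inhibition of serine/threonine-protein kinase 4 (Homo sapiens), read by luminescence and ADP-Glo, with a stated time of 1 h, in the presence of a further agent that is not named here; a higher number here means a weaker inhibitor, a lower number a stronger inhibitor. Compound 1 `CN1C(=O)C(c2c(F)cccc2F)N(C)c2nc(Nc3ccc(S(N)(=O)=O)cc3)ncc21` gives 42 nM, compound 3 `CN1C(=O)C(c2c(F)cccc2F)N(C)c2nc(Nc3ccc(S(=O)(=O)NCC4CC4)cc3)ncc21` gives 79 nM, and compound 2 `CN1C(=O)C(c2c(F)cccc2F)N(C)c2nc(Nc3ccc(S(=O)(=O)N(C)C)cc3)ncc21` gives 181 nM, the highest of the three numbers. The steps of a 4.3-fold higher number from compound 1 to compound 2 (0.63 log units; beyond the scatter) and a 2.3-fold lower number from compound 2 to compound 3 (0.36 log units; beyond the scatter) both concern the sulfonamide nitrogen, as does a 1.9-fold higher number from compound 1 to compound 3 (0.27 log units; within the scatter). Compound 4 `Cc1ccccc1C1C(=O)N(C)c2cnc(Nc3ccc(S(=O)(=O)N(C)C)cc3)nc2N1C` differs from compound 2 elsewhere: 2-methylphenyl in place of 2,6-difluorophenyl on a saturated ring carbon. Going by the values given here, no measured step touches this position, so the measured steps give no guide to the size of this change, and no step beyond the scatter in this assay is expected in either direction. Compound 4 is therefore estimated at 200 nM, within 60 nM to 700 nM, which means an expected step of a 1.1-fold higher number from compound 2 to compound 4 (0.04 log units; within the scatter).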

Compound 4, half-maximal inhibitory concentration: 219 nM
Estimate against measurement, compound 4: 1.1-fold (0.04 log units) below, within the range that was stated.
By their numbers in this assay, from the lowest: compounds 1 and 3 (each within the scatter of the next); then compounds 2 and 4 (each within the scatter of the next).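

In this assay, going by these compounds alone, 2-methylphenyl in place of 2,6-difluorophenyl on the saturated ring carbon gives a 1.2-fold higher number from compound 2 to compound 4 (0.08 log units; within the scatter), the first reading at this position. With dimethylamino on the sulfonyl sulfur, this exchange of both fluorines for one methyl group leaves the number within the scatter. No available evidence bears on why the two groups read alike.

As far as these compounds go, whether the same exchange holds with the amino group of compound 1 on the sulfonyl sulfur remains open. So does the effect of a quite different group here, such as cyclohexyl or an aminomethyl-substituted phenyl.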